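The source may hold more compounds than are shown below. What is called first, only, known or untested is meant among the compounds shown, and "the series" means these compounds.

Measured so far:
compound 1 `Cc1cccc(C(=O)Nc2c(C(O)(C(F)(F)F)C(F)(F)F)ccc3ccccc23)c1` — 23 nM
compound 2 `O=C(Nc1c(C(O)(C(F)(F)F)C(F)(F)F)ccc2ccccc12)c1ccc(I)cc1` — 154 nM

In an assay on LtK cells with ATP-sensitive inward rectifier potassium channel 11 (Homo sapiens) as the target (on this read-out higher numbers stand for an effect only at larger amounts of compound and lower numbers for an effect already at smaller amounts), compound 2 gives 154 nM, the higher of the two numbers; compound 1 gives 23 nM. Compound 3 `O=C(Nc1c(C(O)(C(F)(F)F)C(F)(F)F)ccc2ccccc12)c1cc(Cl)cc(Cl)c1` differs from compound 2 in one place: 3,5-dichlorophenyl in place of 4-iodophenyl on a carbonyl carbon. Going by the values given here, the only measured step at this carbonyl carbon is a 6.7-fold higher number from compound 1 to compound 2 (0.83 log units; beyond the scatter). Among the compounds with values here, it does not cover 3,5-dichlorophenyl itself; it shows only that exchanging the aryl group on this carbonyl carbon can shift the number by that much, and that 3-methylphenyl sits at the lower number. Since 3,5-dichlorophenyl is substituted more like the 3-methylphenyl of compound 1 than like the 4-iodophenyl of compound 2, a lower number than compound 2 is expected, though with wide uncertainty. For compound 3 the estimate is 45 nM, with a range from 12 nM to 160 nM. The step expected is a 3.4-fold lower number from compound 2 to compound 3 (0.53 log units; beyond the scatter), a modest decrease that may or may not clear the scatter.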

Compound 3, half-maximal effective concentration: 306 nM
Compound 3: middle estimate off by 6.8-fold (0.83 log units), on the low side; the whole stated range lies below it.
By their numbers in this assay, from the lowest: compound 1; then compounds 2 and 3 (each within the scatter of the next).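

In this assay the exchange of 4-iodophenyl for 3,5-dichlorophenyl on this carbonyl carbon stays within the scatter (a 2.0-fold higher number from compound 2 to compound 3 (0.30 log units; within the scatter)), so these two aryl groups cannot be told apart here. Set against 3-methylphenyl, the same 3,5-dichlorophenyl group gives a large step (a 13-fold higher number from compound 1 to compound 3 (1.12 log units; beyond the scatter)), which leaves compound 1 as the only one of the three standing clear of the others, while two chlorines at the positions in this name do not reproduce what 3-methylphenyl gives. No measurement on hand bears on the reason for this gap.

Going by these compounds alone, whether the methyl group itself or its substitution pattern sets 3-methylphenyl apart stays open with only three aryl groups to compare. Also open, on these data alone, is how an aryl group carrying an amine or a carboxylic acid, or a saturated ring such as cyclohexyl, would read on this carbonyl carbon.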